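The source may report more compounds than this note shows. Statements on the series, on what has been measured and on what is new or still open speak of the compounds shown alone.

Among the compounds with values here, compound 2 `CNC(=O)c1ccc(-n2c(=O)n(-c3ccc(C#N)c(C(F)(F)F)c3)c3ccccc32)cc1F` gives 8810 nM in a physicochemical assay for solubility (on this read-out higher numbers stand for higher solubility and lower numbers for lower solubility), and stands highest of the two numbers measured so far; compound 1 `Cc1ccc(-n2c(=O)n(-c3ccc(C#N)c(C(F)(F)F)c3)c3ccccc32)cc1` gives 790 nM. Within the data shown here, the one measured step, an 11-fold higher number from compound 1 to compound 2 (1.05 log units; beyond the scatter), is the only one bearing on compound 3 `N#Cc1ccc(-n2c(=O)[nH]c3ccccc32)cc1C(F)(F)F`, which carries hydrogen in place of 3-fluoro-4-(methylcarbamoyl)phenyl on an aromatic nitrogen relative to compound 2. Among the measured compounds shown here, that step brought in the group now removed, so part of it may be given back, though no compound shows the bare ring nitrogen. For compound 3 a step of a 2.9-fold lower number from compound 2 to compound 3 (0.47 log units; beyond the scatter) is expected, downward but not wholly reversing the earlier gain. The estimate for compound 3 is 3000 nM, within 800 nM to 12000 nM.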

Compound 3, solubility: 7900 nM
For compound 3 the middle estimate is 2.6-fold (0.42 log units) below the measured one; low and high end bracket the measured number.
By their numbers in this assay, from the lowest: compound 1; then compounds 3 and 2 (each within the scatter of the next).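

In this assay, hydrogen and 3-fluoro-4-(methylcarbamoyl)phenyl on the aromatic nitrogen read alike (a 1.1-fold lower number from compound 2 to compound 3 (0.05 log units; within the scatter)), so the large group is not needed for the high reading. Only 4-methylphenyl stands apart so far (a 10-fold higher number from compound 1 to compound 3 (1.00 log units; beyond the scatter)), which places the low reading with that group rather than with the shared core. No supporting measurement accounts for this.

As far as these compounds go, it remains open whether methyl on that nitrogen, or a phenyl bearing a carboxylic acid or an amine, reads with compound 1 or with compounds 2 and 3. From the compounds shown here alone, the separate contributions of the fluorine and the methylcarbamoyl group also remain open.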